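A Change of Configuration Alone, Tested for Cytotoxicity

The compounds below may be only part of what the source reports. "The series", "measured", "known", "first", "only" and "open" are said of these compounds alone.

Compound 1 `CC(C)(C)C#Cc1cc(N(C(=O)[C@H]2CC[C@H](C)CC2)[C@H]2CC[C@@H](Oc3ccc(=O)[nH]n3)CC2)c(C(=O)O)s1` has been measured in an ADME assay on MT4 cells (Homo sapiens) for cytotoxicity, with a stated time of 5 days; on this read-out lower numbers stand for higher toxicity in this test and higher numbers for lower toxicity in this test. In this assay compound 1 gives > 20000 nM, which is a limit of the assay and not a number. Two relatives were run alongside it. In this assay compound 2 `CC(C)(C)C#Cc1cc(N(C(=O)[C@H]2CC[C@H](C)CC2)[C@H]2CC[C@@H](Oc3cccnc3)CC2)c(C(=O)O)s1` gives > 20000 nM, again a limit. In this assay compound 3 `C[C@@H](CCOc1cccnc1)N(c1cc(C#CC(C)(C)C)sc1C(=O)O)C(=O)[C@H]1CC[C@H](C)CC1` gives > 20000 nM, also a limit. Within the data shown here, the one change between measured compounds, a step that the two limits leave unreadable from compound 1 to compound 2, therefore cannot be sized, since both ends sit at a limit. Where compound 1 stands is thus known only from one side, and the same holds for its two relatives, as shown by the limit of > 20000 nM in this assay, at which 3 of the 3 values shown sit.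

Compound 4 `CC(C)(C)C#Cc1cc(N(C(=O)[C@H]2CC[C@H](C)CC2)[C@H]2CC[C@H](Oc3ccc(=O)[nH]n3)CC2)c(C(=O)O)s1` is the compound now in question. Relative to compound 1, (the two compounds have the same atoms and bonds and differ only in configuration as drawn: 2 of 4 stereo elements differ; a stereocentre at a saturated ring carbon is drawn s in compound 1 and r in compound 4; a stereocentre at a saturated ring carbon is drawn s in compound 1 and r in compound 4). Among the measured compounds shown here, no measured step bears on a change of configuration alone; the only step available, from compound 1 to compound 2, is unreadable. With every value shown sitting at a limit, no step beyond the scatter is expected in this assay, and the step from compound 1 to compound 4 is expected to be a step that the limit leaves unreadable from compound 1 to compound 4. Compound 4 is therefore estimated at 30000 nM, in a range from 15000 nM to 80000 nM, and is most likely to be reported as a limit once more.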

Compound 4, half-maximal cytotoxic concentration: > 20000 nM
Compound 4: a limit, no number (the forecaster's own chance of this, stated with the estimate: 85%); the middle value lies beyond the limit too.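

Compound 4 ends at a limit, as compound 1 does, so no new step can be read and the change of configuration between them cannot be sized: the limit of > 20000 nM in this assay, at which 4 of the 4 values shown sit.

The compounds shown leave open how far each lies past its limit in this assay, and whether a change of configuration alone shifts this read-out at all.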